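Ring substituent variation on the thiazolethione series

A few compounds are considered here, and "the series" means these few. Any claim that something is new, unique, unknown or untested is made for them only; others in the source may bear on it.

Measured so far:
compound 1, `COc1ccccc1-c1c[nH]c(=S)s1`: 12%
compound 2, `S=c1[nH]cc(-c2ccccc2)s1`: 16%

Both compounds were tested in an assay on isolated protein for inhibition of Indoleamine 2,3-dioxygenase 1 (Homo sapiens), read by colorimetric assay, with stated times of 10 min and 30 min, tested at 100 uM; a lower number here means less inhibition, a higher number more inhibition at the concentration tested (going by the name of the read-out). Compound 1 gives 12% and compound 2 gives 16%; the two numbers sit within the scatter of one another, as the step of a number 4 percentage points higher from compound 1 to compound 2 (within the scatter) shows, so neither can be set apart from the other.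

Compound 3, `Cc1ccc(-c2c[nH]c(=S)s2)cc1`, has not yet been measured. Relative to compound 2 the change is methyl in place of hydrogen on an aromatic carbon. For the measured compounds named here, the only measured step that bears on it, a number 4 percentage points higher from compound 1 to compound 2 (within the scatter), also alters a substituent on the same six-membered ring and stays within the scatter. On that basis no step beyond the scatter is expected from the added methyl. The expected step is therefore no change at the digits printed from compound 2 to compound 3 (within the scatter). Compound 3 is expected to give 16%, within a range of 6% to 28%.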

Compound 3, a percentage reported as inhibition, at one concentration (the size of the read-out at that concentration, not a potency): 15%
Compound 3: the middle estimate sits 1 percentage points above what was measured; measured number inside the range.
By their numbers in this assay, from the lowest: compounds 1, 3 and 2 (each within the scatter of the next).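

In this assay, methyl in place of hydrogen gives a number 1 percentage points lower from compound 2 to compound 3 (within the scatter), which adds a reading on an aromatic carbon of the six-membered ring para to a group of 6 heavy atoms. The earlier step covered only the exchange of methoxy for hydrogen, so this is a second, different substituent change on that ring that stays within the scatter, and compound 2 and compound 3 cannot be set apart. No supporting measurement accompanies this result.

Going by these compounds, a single methyl is a small probe, so it remains open whether a larger or differently built group at this place, such as an amine, a carboxylic acid or a longer alkyl chain, would move the number beyond the scatter from compound 2. The compounds shown also say nothing about changes to the shared core itself.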